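Ethoxy to methoxy: working notes on the series

The source may report more compounds than this note shows. Statements on the series, on what has been measured and on what is new or still open speak of the compounds shown alone.

- compound 1 `COc1ccccc1-c1nnc(SCC(=O)c2ccccc2)o1`: 2070 nM
- compound 2 `O=C(CSc1nnc(-c2ccncc2)o1)c1ccc(Br)cc1`: 4230 nM
- compound 3 `CCOc1ccccc1-c1nnc(SCC(=O)c2ccc(Br)cc2)o1`: 460 nM

All three values come from a functional assay on MCF7 cells (Homo sapiens) for cytotoxicity, read by MTT assay and propidium iodide staining, with a stated time of 24 h; on this read-out lower numbers stand for stronger inhibition and higher numbers for weaker inhibition. Compound 3 holds the lowest of the three numbers at 460 nM. Compound 1 is its nearest neighbour and compound 2 the furthest, and both gaps lie beyond the scatter.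

The next compound to be read is compound 4 `COc1ccccc1-c1nnc(SCC(=O)c2ccc(Br)cc2)o1`. Its difference from compound 3 is hydrogen in place of methyl on a saturated chain carbon bound to an oxygen on an aromatic ring, which turns ethoxy into methoxy.

Among the compounds with values here, no two measured compounds differ in one place only, so this change has no direct precedent. Within the data shown here, the sole measured methoxy compound is compound 1, and it reads higher at 2070 nM than compound 3 does, but that gap cannot be assigned to any single change. A modest move towards a higher number is therefore expected in this assay, near the edge of the scatter or somewhat past it. The expected size is a 1.7-fold higher number from compound 3 to compound 4 (0.24 log units; within the scatter). For compound 4 the estimated value is 800 nM, with an expected range of 300 nM to 2200 nM.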

Compound 4, half-maximal inhibitory concentration: 600 nM
Compound 4: the middle estimate sits 1.3-fold (0.12 log units) above what was measured, within the range that was stated.
By their numbers in this assay, from the lowest: compounds 3 and 4 (each within the scatter of the next); then compound 1; then compound 2.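

In this assay the change of hydrogen in place of methyl on a saturated chain carbon bound to an oxygen on an aromatic ring gives a 1.3-fold higher number from compound 3 to compound 4 (0.12 log units; within the scatter) and so ethoxy and methoxy cannot be told apart at this position, on the evidence of this one pair. Compound 4 also gives the series its other single-place comparisons, as bromo in place of hydrogen on an aromatic carbon gives a 3.5-fold lower number from compound 1 to compound 4 (0.54 log units; beyond the scatter) and 2-methoxyphenyl in place of pyridin-4-yl on an aromatic carbon gives a 7.1-fold lower number from compound 2 to compound 4 (0.85 log units; beyond the scatter) and both of these steps, unlike the ethoxy to methoxy step, lie beyond the scatter. Nothing among the available data offers a reason for any of these steps.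

Going by these compounds, the ethoxy and methoxy pair says nothing about a longer chain such as propoxy, or about an amine or a carboxylic acid, in this place, so how far the position tolerates change remains open. On these data alone, the bromo step rests on one pair carrying methoxy and the pyridin-4-yl step on one pair carrying bromo, so whether either holds with ethoxy, or with another halogen such as chloro, also stays open.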